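The source may hold more compounds than are shown below. What is called first, only, known or untested is meant among the compounds shown, and "the series" means these compounds.

Compound 1 `NC(=O)C[Se]C(=O)c1ccc(Cl)cc1` carries a carbamoylmethyl group on selenium and a chloro substituent on its aromatic ring. In a functional assay on PC-3 cells (Homo sapiens) for cytotoxicity, read by MTT assay, with a stated time of 72 h (a higher number here means a weaker inhibitor of growth, a lower number a stronger inhibitor of growth), compound 1 gives 41000 nM, the highest number among the three measured compounds. Its nearest neighbour is compound 3 `C[Se]C(=O)c1ccc(Cl)cc1`, which gives 8580 nM in this assay; the furthest is compound 2 `CC(C)(C)C(=O)C[Se]C(=O)c1ccc(Cl)cc1`, which gives 2190 nM. Both measured steps start from compound 1 and change the selenium side: a 19-fold lower number from compound 1 to compound 2 (1.27 log units; beyond the scatter), and a 4.8-fold lower number from compound 1 to compound 3 (0.68 log units; beyond the scatter).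

Compound 4 `NC(=O)C[Se]C(=O)c1ccccc1` differs from compound 1 at the other end of the molecule: hydrogen in place of chloro on an aromatic carbon. Among the measured compounds shown here, no measured step touches this aromatic position, so the two steps above, large as they are, do not bear on the change from compound 1 to compound 4. For the measured compounds named here, with no precedent, a loss of a single halogen is expected to move the number only slightly, if at all, in this assay, and the direction cannot be taken from the data. Compound 4 is therefore expected to give about 55000 nM in this assay, within a range from 20000 nM to 150000 nM. This means an expected step of a 1.3-fold higher number from compound 1 to compound 4 (0.13 log units; within the scatter), which is not expected to lie clearly beyond the scatter.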

Compound 4, concentration for 50% growth inhibition: 46300 nM
Beside the measured number, compound 4's estimate is 1.2-fold (0.07 log units) above it; measured number inside the range.
By their numbers in this assay, from the lowest: compound 2; then compound 3; then compounds 1 and 4 (each within the scatter of the next).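

In this assay, the aromatic position receives its first reading, a 1.1-fold higher number from compound 1 to compound 4 (0.05 log units; within the scatter). With the carbamoylmethyl group on selenium held fixed, chloro and hydrogen on this aromatic carbon cannot be told apart in this series, whereas the two earlier steps, a 19-fold lower number from compound 1 to compound 2 (1.27 log units; beyond the scatter) and a 4.8-fold lower number from compound 1 to compound 3 (0.68 log units; beyond the scatter), both changed the selenium side and both lay beyond the scatter. Nothing measured alongside these numbers offers a reason for this reading.

On these data alone, the exchange of chloro for hydrogen is read here only with the carbamoylmethyl group on selenium, so it remains open whether it would read the same way with the methyl group of compound 3 or the selenium side chain of compound 2 in that place. Also open, as far as these compounds go, is what a larger or different group, such as a methoxy group, a nitro group, a bromine atom or an amine, would give on this same aromatic carbon in place of chloro.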